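Pyrazole series: amide to urea step, growth inhibition

A few compounds are considered here, and "the series" means these few. Any claim that something is new, unique, unknown or untested is made for them only; others in the source may bear on it.

Measured so far:
compound 1 `COc1cc(-c2nn(-c3cccc(NC(=O)Nc4cc(C(F)(F)F)cc(C(F)(F)F)c4)c3)cc2-c2ccncc2)ccc1Cl` — 715 nM
compound 2 `COc1cc(-c2nn(-c3cccc(NC(=O)c4cccc(C(F)(F)F)c4)c3)cc2-c2ccncc2)ccc1Cl` — 2310 nM

In a functional assay on SW-620 cells (Homo sapiens) for inhibition, read by sulforhodamine B assay, with a stated time of 48 h (a lower number here means a stronger inhibitor of growth, a higher number a weaker inhibitor of growth), compound 2 gives 2310 nM, the highest of the two numbers; the nearest is compound 1 with 715 nM, a gap beyond the scatter. Compound 3 `COc1cc(-c2nn(-c3cccc(NC(=O)Nc4ccc(Cl)c(Cl)c4)c3)cc2-c2ccncc2)ccc1Cl` differs from compound 2 by (3,4-dichlorophenyl)amino in place of 3-(trifluoromethyl)phenyl on a carbonyl carbon. Since the only urea measured, compound 1, gives 715 nM, the step from compound 2 to compound 3 is expected to lower the number by a 2.9-fold lower number from compound 2 to compound 3 (0.46 log units; beyond the scatter), beyond the scatter. Compound 3 is estimated at 800 nM, within 300 nM to 2500 nM.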

Compound 3, concentration for 50% growth inhibition: 1590 nM
Compound 3: the middle estimate sits 2.0-fold (0.30 log units) below what was measured; low and high end bracket the measured number.
By their numbers in this assay, from the lowest: compound 1; then compounds 3 and 2 (each within the scatter of the next).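

In this assay, (3,4-dichlorophenyl)amino in place of 3-(trifluoromethyl)phenyl on a carbonyl carbon gives a 1.5-fold lower number from compound 2 to compound 3 (0.16 log units; within the scatter). Moving from amide to urea at this place therefore does not by itself give a change beyond the scatter, and this step alters the linking atom and the ring substituents together. No measured evidence bears on this result. Still open, from the compounds shown here alone, is which of those two parts matters, as (3-(trifluoromethyl)phenyl)amino on the same carbonyl carbon would separate them. Also open, going by these compounds, is how a morpholine or a carboxylic acid on that phenyl ring would read.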